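The source may report more compounds than this note shows. Statements on the series, on what has been measured and on what is new or still open speak of the compounds shown alone.

Measured compounds in a functional assay on PC-3 cells (Homo sapiens) for cytotoxicity, read by sulforhodamine B assay, with a stated time of 72 h; on this read-out lower numbers stand for stronger inhibition of growth and higher numbers for weaker inhibition of growth:

compound 1, `O=C(Nc1ccccc1O)C1CCc2ccccc2N1C(=O)c1ccc(Cl)cc1`: 25100 nM
compound 2, `O=C(Nc1ccccc1O)C1CCc2ccccc2N1C(=O)c1ccccc1`: 5690 nM
compound 3, `O=C(Nc1cc(C(F)(F)F)cc(C(F)(F)F)c1)C1CCc2ccccc2N1C(=O)c1ccccc1`: 3500 nM

Compound 2 and compound 1 share a core and differ by chloro in place of hydrogen on an aromatic carbon. For the measured compounds named here, that step, a 4.4-fold higher number from compound 2 to compound 1 (0.64 log units; beyond the scatter), is the only measured step of its kind in the set. Compound 3 carries a different core; the difference between the core of compound 3 and the core of compound 2 is not broken down here, so their two values in this assay are simply read side by side, compound 3 giving 3500 nM and compound 2 giving 5690 nM, which lie within the scatter of each other.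

Compound 4, `O=C(Nc1cc(C(F)(F)F)cc(C(F)(F)F)c1)C1CCc2ccccc2N1C(=O)c1cccc(Cl)c1`, has not yet been measured. It differs from compound 3 by chloro in place of hydrogen on an aromatic carbon. This is the same kind of change as that from compound 2 to compound 1, not the same: there the chloro enters para to a large group, here meta to a large group. The expectation for the step in this assay rests on compound 1, whose step a 4.4-fold higher number from compound 2 to compound 1 (0.64 log units; beyond the scatter) went toward weaker growth inhibition; with the place differing, a smaller step of about a 2.6-fold higher number from compound 3 to compound 4 (0.41 log units; beyond the scatter) is expected. Compound 4 is estimated at 9000 nM, within 3500 nM to 25000 nM.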

Compound 4, concentration for 50% growth inhibition: 1050 nM
The estimate for compound 4 lay 8.6-fold (0.93 log units) above the measured number; the whole stated range lies above it.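

In this assay, chloro in place of hydrogen on an aromatic carbon gives a 3.3-fold lower number from compound 3 to compound 4 (0.52 log units; beyond the scatter), so the change does not carry over in direction or size from the core of compound 2 to the core of compound 3: the same change on two cores in this assay, a 4.4-fold higher number (0.64 log units; beyond the scatter) from compound 2 to compound 1 and a 3.3-fold lower number (0.52 log units; beyond the scatter) from compound 3 to compound 4, 15-fold (1.17 log units) apart, beyond the scatter of two such steps

A step read on one core therefore cannot be transferred to the other core in this series. This does not show what separates the two steps: the cores differ and the chloro also stands at a different place in each pair, and with one pair for each, neither difference can be singled out.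

Open, as far as these compounds go, is how the 3-chlorophenyl group reads on the core of compound 2, and how chloro at the place it holds in compound 1 reads on the core of compound 3; these two comparisons would separate place from core. Also open, from the compounds shown here alone, is whether other groups on the benzoyl ring, such as methoxy, an amine or a carboxylic acid, follow compound 4 or compound 1.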